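The source may report more compounds than this note shows. Statements on the series, on what has been measured and on what is new or still open speak of the compounds shown alone.

Three compounds have been measured in a functional assay on HeLa cells (Homo sapiens) for antiproliferative activity, read by MTT assay, with a stated time of 72 h; on this read-out higher numbers stand for weaker inhibition and lower numbers for stronger inhibition:

Compound 1, `O=C1O/C(=C\Cn2cc(-c3cc(F)cc(F)c3)nn2)C(OCc2ccccc2)=C1OCc1ccccc1`, gives 17700 nM in this assay.
Compound 2, `COc1ccc(-c2cn(C[C@H](O)[C@H]3OC(=O)C(OCc4ccccc4)=C3OCc3ccccc3)nn2)cc1`, gives 16400 nM in this assay.
Compound 3, `O=C1O[C@H]([C@@H](O)Cn2cc(-c3cc(C(F)(F)F)cc(C(F)(F)F)c3)nn2)C(OCc2ccccc2)=C1OCc1ccccc1`, gives 35500 nM in this assay.

All three share the same core and differ only in the group carried on the aromatic ring attached to the triazole. Compound 2 has the lowest number of the three, but compound 1 stands so close that the two cannot be told apart; only compound 3 stands clearly apart, beyond the usual scatter, toward weaker inhibition.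

Compound 4, `CCCCCc1ccc(-c2cn(C[C@H](O)[C@H]3OC(=O)C(OCc4ccccc4)=C3OCc3ccccc3)nn2)cc1`, has not yet been measured in this assay. It differs from compound 2 in one place: pentyl in place of methoxy on an aromatic carbon. The pentyl is a chain of five carbons and carries no hydrogen-bond acceptor, where the methoxy carried one.

For the measured compounds named here, no pair of measured compounds isolates this change, so there is nothing to anchor its size. The three known values all lie within a narrow band, and the groups on that ring vary widely without moving the number far. The step from compound 2 to compound 4 is therefore expected to be small, a 1.4-fold lower number from compound 2 to compound 4 (0.14 log units; within the scatter), most likely within the scatter, with the direction uncertain. Compound 4 is estimated at 12000 nM, in a range from 4000 nM to 40000 nM.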

Compound 4, half-maximal inhibitory concentration: 8390 nM
Beside the measured number, compound 4's estimate is 1.4-fold (0.16 log units) above it; measured number inside the range.
By their numbers in this assay, from the lowest: compounds 4, 2, 1 and 3 (each within the scatter of the next, the first and the last beyond it).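

In this assay, for the compounds shown here, the swap of methoxy for pentyl, on an aromatic carbon para to a large group, gives a 2.0-fold lower number from compound 2 to compound 4 (0.29 log units; within the scatter) and so offers the first direct reading of this position. The step lies within the usual scatter, so it cannot be claimed as a real gain, but it does show that the number holds when a chain of five carbons with no hydrogen-bond acceptor replaces a smaller group that carried one: at this position, neither the acceptor of the methoxy nor the smaller size of that group is needed to keep the number where it stands. Nothing available explains why the number holds, so the result stays a plain observation about this one pair.

Going by these compounds, it remains open whether a longer chain such as octyl or a shorter one such as ethyl would move the number beyond the scatter, and what an amine or a carboxylic acid would do at the same place. A single step also cannot say whether pentyl in place of methoxy would give a similar result on a compound that differs elsewhere.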